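Nitroimidazole rearrangement on a quinazoline cytotoxicity series

This account rests on a few compounds, and the source may have more. Where it says the series, first, only, none or still open, it means among the compounds named here.

Compound 1: `COc1cc2ncnc(Nc3ccc(F)c(Cl)c3)c2cc1OCCCCCn1ccnc1[N+](=O)[O-]`, 5590 nM in a functional assay on HT-29 cells (Homo sapiens) for cytotoxicity, read by sulforhodamine B assay, with a stated time of 72 h; on this read-out higher numbers stand for weaker inhibition and lower numbers for stronger inhibition
Compound 2: `COc1cc2ncnc(Nc3ccc(OCc4cccc(F)c4)c(Cl)c3)c2cc1OCCCn1ccnc1[N+](=O)[O-]`, 20000 nM in this assay

Compound 1 gives the lowest number of the two, with compound 2 at 20000 nM in this assay, a gap beyond the scatter. Compound 3, `COc1cc2ncnc(Nc3ccc(F)c(Cl)c3)c2cc1OCCCCn1c([N+](=O)[O-])cnc1C`, is unmeasured; it differs from compound 1 by 2-methyl-5-nitro-1H-imidazol-1-yl in place of (2-nitro-1H-imidazol-1-yl)methyl on a saturated chain carbon, four bonds along the chain from an oxygen on an aromatic ring, the same atoms joined differently. Going by the values given here, no step between measured compounds shows this change, so no direction is established. The move from compound 1 to compound 3 is expected to stay within the scatter, a 1.3-fold higher number from compound 1 to compound 3 (0.10 log units; within the scatter). Compound 3 is therefore estimated at 7000 nM, in the range 2000 nM to 25000 nM.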

Compound 3, half-maximal inhibitory concentration: 9980 nM
The estimate for compound 3 lay 1.4-fold (0.15 log units) below the measured number; the range from low to high includes it.
By their numbers in this assay, from the lowest: compounds 1, 3 and 2 (each within the scatter of the next, the first and the last beyond it).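

In this assay, going by these compounds alone, putting 2-methyl-5-nitro-1H-imidazol-1-yl in place of (2-nitro-1H-imidazol-1-yl)methyl on a saturated chain carbon gives a 1.8-fold higher number from compound 1 to compound 3 (0.25 log units; within the scatter) and is the first single-place comparison here. At this position, rejoining the same atoms does not separate the two compounds. No measurement shown offers an explanation for this result. Still open, on these data alone, is whether a longer chain bearing 2-methyl-5-nitro-1H-imidazol-1-yl, or an amine in place of that group, would move the number beyond the scatter.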